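Working notes: chain length from compound 3 to compound 4

The source may hold more compounds than are shown below. What is called first, only, known or untested is meant among the compounds shown, and "the series" means these compounds.

Measured in a functional assay on NCI-H1650 cells (Homo sapiens) for cytotoxicity, read by MTT assay, with a stated time of 48 h; a higher number here means a weaker inhibitor, a lower number a stronger inhibitor
- compound 1 `CC(C)COc1ccc2c(Cl)ccnc2c1` gives 2100 nM
- compound 2 `CCCCOc1ccc2c(Cl)ccnc2c1` gives 2570 nM
- compound 3 `CCCCCCOc1ccc2c(Cl)ccnc2c1` gives 2080 nM

Compound 3 stands within the scatter of both other compounds, with a 1.0-fold lower number from compound 1 to compound 3 (0.00 log units; within the scatter) and a 1.2-fold lower number from compound 2 to compound 3 (0.09 log units; within the scatter) as its steps. The third measured step, a 1.2-fold higher number from compound 1 to compound 2 (0.09 log units; within the scatter) as well, stays within the scatter. The next structure is compound 4 `CCOc1ccc2c(Cl)ccnc2c1` with hydrogen in place of butyl on a saturated chain carbon, two bonds along the chain from an oxygen on an aromatic ring as the change, hydrogen in place of butyl on a saturated chain carbon, two bonds along the chain from an oxygen on an aromatic ring. This hexyl to ethyl cut leaves a chain shorter than any measured so far, so the data do not cover it directly. From the flat steps in this assay no step beyond the scatter is expected, in either direction. The expected step is a 1.2-fold higher number from compound 3 to compound 4 (0.06 log units; within the scatter) and it lies inside the scatter. Compound 4 is estimated at 2400 nM with an expected range from 1200 nM to 4800 nM as its two ends.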

Compound 4, half-maximal inhibitory concentration: 3340 nM
Beside the measured number, compound 4's estimate is 1.4-fold (0.14 log units) below it; measured number inside the range.
By their numbers in this assay, from the lowest: compounds 3, 1, 2 and 4 (each within the scatter of the next).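

In this assay, cutting hexyl to ethyl at this place on the chain gives a 1.6-fold higher number from compound 3 to compound 4 (0.21 log units; within the scatter), while the other two steps to the ethyl chain give a 1.3-fold higher number from compound 2 to compound 4 (0.11 log units; within the scatter) and a 1.6-fold higher number from compound 1 to compound 4 (0.20 log units; within the scatter). The flat picture among the longer chains therefore extends to the shortest chain in the set, and no chain among the four compounds separates from the others. No available evidence accounts for this flatness.

Still open, as far as these compounds go, is whether a chain longer than hexyl would leave the scatter. From the compounds shown here alone, an amine or a carboxylic acid at the chain end also remains untested here.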